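The source may hold more compounds than are shown below. What is called first, only, known or untested is meant among the compounds shown, and "the series" means these compounds.

In a functional assay on CHO cells with adenosine receptor A1 (Homo sapiens) as the target, read by cAMP accumulation and immunoassay, with a stated time of 6 min, tested at 1 uM (a lower number here means a stronger effect, a higher number a weaker effect of the compound at the concentration tested), compound 1 `Nc1scc(CN2CCN(c3ccc(Cl)cc3F)CC2)c1C(=O)c1ccc(Cl)cc1` gives -57%, the lowest of the two values at hand. Compound 2 `Nc1scc(CN2CCN(c3cccc(F)c3)CC2)c1C(=O)c1cccc(C(F)(F)F)c1` gives -35% in this assay, a weaker effect that lies beyond the scatter of compound 1. Compound 3 `Nc1scc(CN2CCN(c3cc(F)ccc3F)CC2)c1C(=O)c1ccc(Cl)cc1` differs from compound 1 in one place: 2,5-difluorophenyl in place of 4-chloro-2-fluorophenyl on an amine nitrogen in a ring. Within the data shown here, no measured pair shows this kind of exchange, so its size is open. The expected step in this assay is a modest weakening, a number 12 percentage points higher from compound 1 to compound 3 (beyond the scatter), close to the edge of the scatter. Compound 3 is therefore estimated at -45%, with a range from -70% to -20%.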

Compound 3, a percentage reported as activity, at one concentration (the size of the read-out at that concentration, not a potency): -59%
Compound 3: middle estimate off by 14 percentage points, on the high side; low and high end bracket the measured number.
By their numbers in this assay, from the lowest: compounds 3 and 1 (each within the scatter of the next); then compound 2.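

In this assay, placing 2,5-difluorophenyl on the amine nitrogen in the ring instead of 4-chloro-2-fluorophenyl gives a number 2 percentage points lower from compound 1 to compound 3 (within the scatter), so this position tolerates the exchange. The chlorine can leave and a second fluorine can enter with no change in the read-out beyond the scatter. No measurement at hand accounts for this result. As far as these compounds go, whether a methoxy group on this phenyl would hold the read-out remains open, as does the outcome with an unsubstituted phenyl or a pyridine in its place.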